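The source may hold more compounds than are shown below. What is called first, only, known or untested is meant among the compounds shown, and "the series" means these compounds.

Series so far:
- compound 1 `COc1ccc(S(=O)(=O)Nc2cccc3cc(Cl)[nH]c23)cc1` gives 0.11 ug/mL
- compound 2 `COc1ccc(S(=O)(=O)Nc2cccc3c(Cl)c[nH]c23)cc1` gives 0.76 ug/mL
- compound 3 `O=S(=O)(Nc1cccc2cc(Cl)[nH]c12)c1ccc(Cl)cc1` has no value yet

In a functional assay on P388 cells (Mus musculus) for antiproliferative activity, read by colorimetric assay and MTT assay (a higher number here means a weaker inhibitor, a lower number a stronger inhibitor), compound 1 at 0.11 ug/mL holds the lower of the two numbers and is the stronger inhibitor. Compound 2 at 0.76 ug/mL stands higher, beyond the scatter.

Compound 3 keeps the core of compound 1 and carries chloro in place of methoxy on an aromatic carbon, para to a large group: chloro in place of methoxy on an aromatic carbon. Among the compounds with values here, no measured pair contains this change, so the data offer no direct guide to it. In this assay no step beyond the scatter is expected, and no firm direction can be given. The estimated change is a 1.2-fold higher number from compound 1 to compound 3 (0.07 log units; within the scatter) and it is expected to stay within the scatter. Compound 3 is expected at 0.13 ug/mL with an estimated range of 0.04 ug/mL to 0.45 ug/mL in this assay once measured.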

Compound 3, half-maximal inhibitory concentration: 7.4 ug/mL
Compound 3: middle estimate off by 57-fold (1.76 log units), on the low side; the measured number lies above the stated range.
By their numbers in this assay, from the lowest: compound 1; then compound 2; then compound 3.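

In this assay there is a 67-fold higher number from compound 1 to compound 3 (1.83 log units; beyond the scatter) with chloro in place of methoxy on an aromatic carbon, para to a large group. Within the data shown here, this is the first measured step at this position, and it shows that the position is far from indifferent: on the core of compound 1, this single exchange weakens inhibition by a large margin. No measurement in hand bears on why the step is so large.

The compounds shown leave open whether the methoxy itself is what matters or whether chloro is what harms, and a hydrogen, an ethoxy or an amine at the same place would help separate the two. Going by these compounds, it also remains open whether the same exchange would weigh as heavily on the core of compound 2.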